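The source may report more compounds than this note shows. Statements on the series, on what has been measured and on what is new or still open speak of the compounds shown alone.

Values in a functional assay on HepG2 cells (Homo sapiens) for cytotoxicity, read by MTT assay, with a stated time of 48 h; a higher number here means a weaker inhibitor, a lower number a stronger inhibitor:
Compound 1 `COC(=O)c1ccccc1OCc1cn(-c2ccc(S(=O)(=O)N3CCc4ccccc4C3)cc2)nn1`: 12400 nM
Compound 2 `COc1cc2c(cc1OC)CN(S(=O)(=O)c1ccc(-n3cc(COc4ccc(C)cc4)nn3)cc1)CC2`: 560 nM
Compound 3 `O=S(=O)(c1ccc(-n2cc(COc3ccc4ccccc4c3)nn2)cc1)N1CCc2ccccc2C1`: 60500 nM

Compound 2, at 560 nM, holds the lowest number of the three, with compound 1 the nearest and compound 3 the furthest. The change under study leads to compound 4 `COc1cc2c(cc1OC)CN(S(=O)(=O)c1ccc(-n3cc(CO)nn3)cc1)CC2`: hydrogen in place of 4-methylphenyl on an oxygen on a saturated carbon. In other words, 4-methylphenoxy gives way to hydroxy.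

Within the data shown here, only one measured step touches the same oxygen: a 4.9-fold higher number from compound 1 to compound 3 (0.69 log units; beyond the scatter). It was modest but beyond the scatter. That step exchanges one ring-bearing group for another, whereas here the ring is lost and hydrogen takes its place, so it is only a rough guide. Among the measured compounds shown here, no measured compound carries hydroxymethyl. Since compound 2 sits at the low end of the series, a higher number is expected in this assay, probably a larger move than the measured step. The step expected is a 7.1-fold higher number from compound 2 to compound 4 (0.85 log units; beyond the scatter). For compound 4 the estimated value is 4000 nM, with an expected range from 700 nM to 30000 nM.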

Compound 4, half-maximal inhibitory concentration: 31800 nM
Estimate against measurement, compound 4: 8.0-fold (0.90 log units) below; measured number above the stated range.
By their numbers in this assay, from the lowest: compound 2; then compound 1; then compounds 4 and 3 (each within the scatter of the next).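

Cutting 4-methylphenoxy back to hydroxy gives a 57-fold higher number from compound 2 to compound 4 (1.75 log units; beyond the scatter) in this assay. On the core of compound 2, the 4-methylphenyl on this oxygen therefore goes with the low number, and losing it moves the number further than the ring-for-ring exchange of a 4.9-fold higher number from compound 1 to compound 3 (0.69 log units; beyond the scatter), although that step stands on another core. The data at hand give no reason for the size of the new step.

Still open, as far as these compounds go, is whether the aromatic ring itself matters or whether any group on this oxygen would keep the number low; a methyl ether, a benzyl ether or an aminomethyl in place of hydroxymethyl would separate these cases. Also open, from the compounds shown here alone, is whether 4-methylphenyl would act the same way on the core of compound 1.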